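Benzamide in place of urea: a step without a precedent

The source may report more compounds than this note shows. Statements on the series, on what has been measured and on what is new or still open speak of the compounds shown alone.

Compound 1 `COc1cc(-c2nn(-c3cccc(NC(=O)Nc4cc(C(F)(F)F)cc(C(F)(F)F)c4)c3)cc2-c2ccncc2)ccc1Cl`: 933 nM
Compound 2 `COc1cc(-c2nn(-c3cccc(NC(=O)Nc4cccc(C(F)(F)F)c4)c3)cc2-c2ccncc2)ccc1Cl`: 751 nM
Compound 3 `O=C(Nc1cccc(-n2cc(-c3ccncc3)c(-c3ccc(Cl)c(O)c3)n2)c1)Nc1cc(C(F)(F)F)cc(C(F)(F)F)c1`: 540 nM

In a functional assay on MCF7 cells (Homo sapiens) for inhibition, read by sulforhodamine B assay, with a stated time of 48 h (on this read-out lower numbers stand for stronger inhibition of growth and higher numbers for weaker inhibition of growth), compound 2 gives 751 nM, the second highest of the three numbers; compound 1 lies a little higher and compound 3 a little lower, both within the scatter. Compound 4 `COc1cc(-c2nn(-c3cccc(NC(=O)c4ccccc4)c3)cc2-c2ccncc2)ccc1Cl` differs from compound 2 by phenyl in place of (3-(trifluoromethyl)phenyl)amino on a carbonyl carbon. The two measured steps, a 1.2-fold lower number from compound 1 to compound 2 (0.09 log units; within the scatter) and a 1.7-fold lower number from compound 1 to compound 3 (0.24 log units; within the scatter), concern other places and were both small, so they give no direct guidance on removing the (3-(trifluoromethyl)phenyl)amino group. With its hydrogen-bond donor gone, a shift toward weaker inhibition is expected, of the size a 4.0-fold higher number from compound 2 to compound 4 (0.60 log units; beyond the scatter), with wide uncertainty. Compound 4 is estimated at 3000 nM, between 800 nM and 12000 nM.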

Compound 4, concentration for 50% growth inhibition: 335 nM
Compound 4: the middle estimate sits 9.0-fold (0.95 log units) above what was measured, outside the stated range (below it).
By their numbers in this assay, from the lowest: compounds 4, 3, 2 and 1 (each within the scatter of the next, the first and the last beyond it).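

In this assay, the (3-(trifluoromethyl)phenyl)amino group on the carbonyl carbon is not needed for growth inhibition: phenyl in its place gives a 2.2-fold lower number from compound 2 to compound 4 (0.35 log units; beyond the scatter), even though the hydrogen-bond donor leaves with that group. This is the first step among these compounds that lies beyond the scatter, and it shows that this position, unlike the two places changed earlier, can shift the number, though only modestly. Nothing available explains the direction of the step.

Going by these compounds, it remains open whether an amine or a carboxylic acid on the phenyl of compound 4 would keep this level of inhibition. Also open, on these data alone, is whether a longer chain on the carbonyl carbon would be tolerated in place of phenyl.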